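Pushing the amide substituent toward a simple diol

A few compounds are considered here, and "the series" means these few. Any claim that something is new, unique, unknown or untested is made for them only; others in the source may bear on it.

Measured so far:
compound 1, `CCn1c(C(=O)N[C@@H](CC(=O)OC)C(=O)OC)ccc1C(CC)(CC)c1ccc(OCS(=O)(=O)c2ccccc2)c(C)c1`, 6490 nM
compound 2, `CCn1c(C(=O)N[C@@H](CO)C(C)C)ccc1C(CC)(CC)c1ccc(OCS(=O)(=O)c2ccccc2)c(C)c1`, 10600 nM
Not yet measured:
compound 3, `CCn1c(C(=O)N[C@H](CO)CCO)ccc1C(CC)(CC)c1ccc(OCS(=O)(=O)c2ccccc2)c(C)c1`

All three compounds share one core and differ only in the group carried on the amide-type nitrogen. In a functional assay on PC-3 cells (Homo sapiens) for antiproliferative activity, read by MTT assay, with a stated time of 24 h (a lower number here means a stronger inhibitor, a higher number a weaker inhibitor), compound 1 gives 6490 nM, the lower of the two numbers measured, though its gap to compound 2 is within the scatter; compound 2 gives 10600 nM. The step of a 1.6-fold higher number from compound 1 to compound 2 (0.21 log units; within the scatter) shows that exchanging the two methoxycarbonyl groups for a chain bearing a hydroxymethyl leaves the number within the scatter. Compound 3 takes a related route: 3-hydroxy-1-(hydroxymethyl)propyl in place of 1,2-bis(methoxycarbonyl)ethyl on an amide-type nitrogen. For the measured compounds named here, the only measured step that bears on this is the one from compound 1 to compound 2, which likewise trades the methoxycarbonyl groups for a hydroxyl-bearing chain, and it stayed within the scatter. The expected step of a 1.4-fold higher number from compound 1 to compound 3 (0.14 log units; within the scatter) is therefore small, leaning if anything toward a higher number. Compound 3 is estimated at 9000 nM in this assay, with a range from 4000 nM to 20000 nM.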

Compound 3, half-maximal inhibitory concentration: 12100 nM
Beside the measured number, compound 3's estimate is 1.3-fold (0.13 log units) below it; the measured number falls inside the stated range.
By their numbers in this assay, from the lowest: compounds 1, 2 and 3 (each within the scatter of the next).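

In this assay, replacing 1,2-bis(methoxycarbonyl)ethyl on the amide-type nitrogen with 3-hydroxy-1-(hydroxymethyl)propyl gives a 1.9-fold higher number from compound 1 to compound 3 (0.27 log units; within the scatter), so a group carrying hydroxyl groups instead of methoxycarbonyl groups still leaves the read-out unresolved from that of the diester. The new group also cannot be separated from 1-(hydroxymethyl)-2-methylpropyl, with a 1.1-fold higher number from compound 2 to compound 3 (0.06 log units; within the scatter), which shows that exchanging the branched carbon end of that group for a hydroxyl-bearing chain makes no measurable difference here. All three compounds therefore lie within the scatter of one another, a flat picture across these three groups for which no supporting measurement offers an explanation.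

The compounds shown leave open whether a different kind of group on this nitrogen, such as an amine, a carboxylic acid or a longer chain, would move the number beyond the scatter. Going by these compounds, it also remains open whether the mirror-image arrangement at the defined stereocentre of 3-hydroxy-1-(hydroxymethyl)propyl would change the number.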